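Replacing a large side group with cyclopropyl

This account rests on a few compounds, and the source may have more. Where it says the series, first, only, none or still open, it means among the compounds named here.

Compound 1 `O=C1O[C@H]([C@@H](O)Cn2cc(-c3cccc(O)c3)nn2)C(OCc2ccccc2)=C1OCc1ccccc1`: 39300 nM
Compound 2 `COc1ccccc1-c1cn(C[C@H](O)[C@H]2OC(=O)C(OCc3ccccc3)=C2OCc2ccccc2)nn1`: > 100000 nM (a limit of the assay, not a number)
Compound 3 `O=C1O[C@H]([C@@H](O)Cn2cc(CNS(=O)(=O)c3ccc(F)cc3)nn2)C(OCc2ccccc2)=C1OCc1ccccc1`: 25000 nM

All three results come from a functional assay on HeLa cells (Homo sapiens) for antiproliferative activity, read by MTT assay, with a stated time of 72 h; on this read-out higher numbers stand for weaker inhibition and lower numbers for stronger inhibition. Going by the values given here, compound 1 and compound 3 are the only two with true numbers, and the gap between them is a 1.6-fold lower number from compound 1 to compound 3 (0.20 log units; within the scatter). Compound 4 `O=C1O[C@H]([C@@H](O)Cn2cc(C3CC3)nn2)C(OCc2ccccc2)=C1OCc1ccccc1` shares the core of compound 3, and the difference is cyclopropyl in place of (((4-fluorophenyl)sulfonyl)amino)methyl on an aromatic carbon. In words, cyclopropyl replaces (((4-fluorophenyl)sulfonyl)amino)methyl on an aromatic carbon of the five-membered aromatic ring with 3 nitrogen.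

The two steps into compound 3 swap groups at this same carbon, so both bear on the change. The step above stayed small, while the other was an at least 4.0-fold lower number from compound 2 to compound 3 (0.60 log units; beyond the scatter). Neither involves cyclopropyl, so they guide the size of the change only loosely. A modest rise in the number is expected, namely a 2.2-fold higher number from compound 3 to compound 4 (0.34 log units; beyond the scatter). For compound 4 the estimated value is 55000 nM, with an expected range from 20000 nM to 130000 nM.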

Compound 4, half-maximal inhibitory concentration: 26500 nM
Estimate against measurement, compound 4: 2.1-fold (0.32 log units) above; measured number inside the range.
By their numbers in this assay, from the lowest: compounds 3, 4 and 1 (each within the scatter of the next). At a limit, above all of these: compound 2.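

Replacing (((4-fluorophenyl)sulfonyl)amino)methyl with the much smaller cyclopropyl leaves activity unchanged as far as this assay can tell: a 1.1-fold higher number from compound 3 to compound 4 (0.03 log units; within the scatter). Cyclopropyl also matches 3-hydroxyphenyl, with a 1.5-fold lower number from compound 1 to compound 4 (0.17 log units; within the scatter), so a six-membered aromatic ring on this carbon is not needed to hold this level of activity in these compounds. Compound 2 alone stands apart, and its result is a limit of the assay rather than a number, so an at least 3.7-fold lower number from compound 2 to compound 4 (0.57 log units; beyond the scatter) gives only a minimum size for that step: the limit of > 100000 nM in this assay, at which 1 of the 4 values shown sits.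

From the compounds shown here alone, it remains open whether a methyl group, an amine or a carboxylic acid on this carbon would move the number beyond the scatter. Also open, going by these compounds, is whether the shared core, rather than this side group, sets the level seen for compound 1, compound 3 and compound 4.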